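Swapping the Pyridine on the Amide Nitrogen of Compound 1

The source may report more compounds than this note shows. Statements on the series, on what has been measured and on what is new or still open speak of the compounds shown alone.

Compound 1 `Cc1ccc(OCC(=O)N(Cc2cccs2)c2ccccn2)cc1` is the more active of the two measured compounds in an assay on HEK293 cells for agonist activity at transient receptor potential cation channel subfamily M member 8 (Homo sapiens), read by fluorescence and calcium flux, with a stated time of 15 min; on this read-out higher numbers stand for an effect only at larger amounts of compound and lower numbers for an effect already at smaller amounts. In this assay compound 1 gives 200 nM, the lowest of the two numbers recorded. Its neighbour on the numbers, compound 2 `CCN(Cc1ccccn1)C(=O)COc1ccc(C)cc1`, gives 16000 nM in this assay, a gap that lies well beyond the usual scatter. Among the compounds with values here, no single-point step between the two measured compounds is available, since they differ in more than one place.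

Compound 3 `Cc1ccc(OCC(=O)N(Cc2cccs2)c2ccon2)cc1` has not yet been measured in this assay. It is derived from compound 1 by one change: 1,2-oxazol-3-yl in place of pyridin-2-yl on an amide-type nitrogen. The ring that enters carries one more hydrogen-bond acceptor and one fewer heavy atom than the ring that leaves, and it is five-membered rather than six-membered.

Within the data shown here, with no measured step of this kind to lean on, the expected step from compound 1 to compound 3 is a modest rise in this assay, a 2.5-fold higher number from compound 1 to compound 3 (0.40 log units; beyond the scatter), which may still fall within the scatter. Compound 3 is therefore estimated at 500 nM in this assay, within a range of 150 nM to 2500 nM.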

Compound 3, half-maximal effective concentration: 2 nM
Beside the measured number, compound 3's estimate is 250-fold (2.40 log units) above it; the measured number lies below the stated range.
By their numbers in this assay, from the lowest: compound 3; then compound 1; then compound 2.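

Within the data shown here, the step of a 100-fold lower number from compound 1 to compound 3 (2.00 log units; beyond the scatter) in this assay is the first reading of a single change, since compound 1 and compound 2 differ in more than one place. It shows that the group on the amide-type nitrogen, whose other neighbours are the carbonyl carbon and a saturated chain carbon, strongly governs the response on this read-out, and that pyridin-2-yl is not required there: 1,2-oxazol-3-yl, a five-membered aromatic ring with two hetero atoms, takes its place with a large gain. Nothing at hand accounts for the size of this step.

The change alters ring size, hetero atoms and hydrogen-bond acceptors in one move, so the compounds shown do not assign the step to any one of these, and it remains open whether 1,3-oxazol-2-yl, 1,3-thiazol-2-yl or pyrimidin-2-yl on the same nitrogen would behave like 1,2-oxazol-3-yl or like pyridin-2-yl. As far as these compounds go, it is also open whether the step would hold with the thiophene-bearing chain replaced by a benzyl group, or with a chlorine atom in place of the methyl group on the aryl ether.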